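Nitro-to-amino exchange on a second aminopyridine core

The source may hold more compounds than are shown below. What is called first, only, known or untested is meant among the compounds shown, and "the series" means these compounds.

The series comprises four compounds built on closely related cores. Compound 1 `CCCCC(O)C(C)Nc1cc(NC(=O)OCC)nc(N)c1[N+](=O)[O-]` and compound 2 `CCCCC(Nc1cc(NC(=O)OCC)nc(N)c1[N+](=O)[O-])C(C)O` share the same atoms joined differently; their cores differ as follows: 1-(1-hydroxyethyl)pentyl in place of 2-hydroxy-1-methylhexyl on a nitrogen on an aromatic ring. Compound 3 `CCCCC(O)C(C)Nc1cc(NC(=O)OCC)nc(N)c1N` is derived from compound 1, and compound 4 `CCCCC(Nc1cc(NC(=O)OCC)nc(N)c1N)C(C)O`, not yet measured, is derived from compound 2 in the same way.

In a functional assay on L1210 cells (Mus musculus), with a stated time of 48 h (on this read-out lower numbers stand for stronger inhibition and higher numbers for weaker inhibition), compound 1 gives 55000 nM. Compound 2 gives 56000 nM in this assay, so that the step of a 1.0-fold higher number from compound 1 to compound 2 (0.01 log units; within the scatter) shows no separation between the two cores. Compound 3 gives 18000 nM in this assay. The change from compound 1 to compound 3 is amino in place of nitro on an aromatic carbon, and it produced the step of a 3.1-fold lower number from compound 1 to compound 3 (0.49 log units; beyond the scatter).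

The change from compound 2 to compound 4 is amino in place of nitro on an aromatic carbon. Its surroundings are described in the same words as for the change from compound 1 to compound 3, so it is the same change on the other core. Because the cores of compound 1 and compound 2 gave the step of a 1.0-fold higher number from compound 1 to compound 2 (0.01 log units; within the scatter), the expectation for compound 4 rests on carrying over the step seen from compound 1 to compound 3. The step from compound 2 to compound 4 in this assay is therefore expected to be about a 3.1-fold lower number from compound 2 to compound 4 (0.49 log units; beyond the scatter). On that basis compound 4 is estimated at 18000 nM in this assay. Going by the values given here, the estimate for compound 4 is expected to lie between 9000 nM and 36000 nM, since only one earlier instance of this change supports it.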

Compound 4, half-maximal inhibitory concentration: 1700 nM
Beside the measured number, compound 4's estimate is 11-fold (1.02 log units) above it; the whole stated range lies above it.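

Amino in place of nitro on an aromatic carbon lowers the number in this assay on the second core as well, but the step there is much larger: a 33-fold lower number from compound 2 to compound 4 (1.52 log units; beyond the scatter). Set beside the earlier step, the direction carries over from one core to the other while the size does not: the same change on two cores in this assay, a 3.1-fold lower number (0.49 log units; beyond the scatter) from compound 1 to compound 3 and a 33-fold lower number (1.52 log units; beyond the scatter) from compound 2 to compound 4, 11-fold (1.03 log units) apart, beyond the scatter of two such steps. This shows that, across these two instances, the size of the change on one core did not predict its size on the other, even though the nitro compounds on the two cores show no separation, with a 1.0-fold higher number from compound 1 to compound 2 (0.01 log units; within the scatter); it does not show why the two steps differ, and two instances establish no rule for the series.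

The compounds shown leave open whether the larger step stays with the 1-(1-hydroxyethyl)pentyl group or would also appear with a longer chain on the same nitrogen, such as a 1-(1-hydroxyethyl)heptyl group. They also leave open how a methylamino or acetylamino group would compare with amino at the same place on each core, and whether such groups would show the same gap between the two steps.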